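Swapping a phenol-ether ring for a chlorophenyl ring

The compounds below may be only part of what the source reports. "The series", "measured", "known", "first", "only" and "open" are said of these compounds alone.

Compound 1 `COc1cc(/C=C2\CCC/C(=C\c3ccc([N+](=O)[O-])cc3)C2=O)ccc1O` belongs to a small set of dibenzylidene ketones tested in a functional assay on HSC-2 cells (Homo sapiens) for cytotoxicity (on this read-out higher numbers stand for lower toxicity in this test and lower numbers for higher toxicity in this test), where compound 1 gives 2800 nM. Compound 2 `COc1ccc(/C=C2\CCC/C(=C\c3ccc([N+](=O)[O-])cc3)C2=O)cc1OC` gives 2300 nM, and compound 3 `O=C1/C(=C/c2ccc(O)cc2)Cc2ccccc2/C1=C\c1ccc([N+](=O)[O-])cc1`, built on a different core, gives 5200 nM. Among these three numbers compound 1 stands second highest, and its gaps to both neighbours are within the usual scatter. Among the measured compounds shown here, the only single-point step is the one from compound 1 to compound 2, where a methyl replaces a hydrogen on an oxygen of the aromatic ring: a 1.2-fold lower number from compound 1 to compound 2 (0.09 log units; within the scatter).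

Compound 4 `O=C1/C(=C/c2ccc(Cl)cc2)CCC/C1=C\c1ccc([N+](=O)[O-])cc1` differs from compound 1 by 4-chlorophenyl in place of 4-hydroxy-3-methoxyphenyl on a double-bonded chain carbon bound to a double-bonded ring carbon. For the measured compounds named here, no measured pair exchanges this whole ring, so the one step available says only that a small change on that ring left the number where it was. On that basis the expected step from compound 1 to compound 4 is a 1.1-fold lower number from compound 1 to compound 4 (0.03 log units; within the scatter), none beyond the scatter. Compound 4 is therefore estimated at 2600 nM, with a range from 900 nM to 7500 nM.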

Compound 4, half-maximal cytotoxic concentration: 1500 nM
The estimate for compound 4 lay 1.7-fold (0.24 log units) above the measured number; the measured number falls inside the stated range.
By their numbers in this assay, from the lowest: compounds 4, 2, 1 and 3 (each within the scatter of the next, the first and the last beyond it).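

In this assay, exchanging the whole 4-hydroxy-3-methoxyphenyl ring for 4-chlorophenyl gives a 1.9-fold lower number from compound 1 to compound 4 (0.27 log units; within the scatter) and so stays within the scatter, even though the ring changes far more here than in the earlier step, which only added a methyl on one of its oxygens. For this pair, then, the hydroxy and methoxy groups can both go and a chlorine can come in, leaving the ring with no hydrogen-bond donors or acceptors, without a number that can be told apart from that of compound 1. No measurement here offers an explanation for this result.

Going by these compounds, whether an amine or a carboxylic acid in place of the chlorine would move the number beyond the scatter stays open. On these data alone, it is also open whether the same ring exchange would give a similar result on the core of compound 3.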